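Replacing 2-fluorophenyl with 3-methylthiophen-2-yl

This account rests on a few compounds, and the source may have more. Where it says the series, first, only, none or still open, it means among the compounds named here.

In a functional assay on DU-145 cells (Homo sapiens) for inhibition, read by trypan blue exclusion, with a stated time of 96 h (a higher number here means a weaker inhibitor of growth, a lower number a stronger inhibitor of growth), compound 2 `Cc1ccc(CS/C(=C/c2ccccc2F)C(=O)c2ccc(Cl)cc2)cc1` gives 10000 nM. Compound 1 `Cc1ccc(CS/C(=C/c2ccc(O)cc2)C(=O)c2ccc(Cl)cc2)cc1` gives 10000 nM, level with compound 2, and together they hold the lowest number of the three measured. Compound 3 `O=C(/C(=C\c1cc(Br)c(O)c(Br)c1)S(=O)(=O)Cc1ccc(Br)cc1)c1ccc(Br)cc1` gives a higher 25000 nM. Compound 4 `Cc1ccc(CS/C(=C/c2sccc2C)C(=O)c2ccc(Cl)cc2)cc1` is still unmeasured. Its difference from compound 2 is 3-methylthiophen-2-yl in place of 2-fluorophenyl on a double-bonded chain carbon bound to a double-bonded chain carbon. For the measured compounds named here, the only measured step at this place, 2-fluorophenyl in place of 4-hydroxyphenyl, shows no change at the digits printed from compound 1 to compound 2 (within the scatter). No step beyond the scatter is therefore expected in either direction, although one step is slender evidence. The expected outcome is no change at the digits printed from compound 2 to compound 4 (within the scatter). For compound 4 the estimated value is 10000 nM, with an expected range of 4000 nM to 25000 nM.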

Compound 4, concentration for 50% growth inhibition: 10000 nM
Estimate against measurement, compound 4: no gap at the digits printed; low and high end bracket the measured number.
By their numbers in this assay, from the lowest: compounds 1, 2 and 4 (each within the scatter of the next); then compound 3.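

In this assay, putting 3-methylthiophen-2-yl on a double-bonded chain carbon bound to a double-bonded chain carbon gives no change at the digits printed from compound 2 to compound 4 (within the scatter) and no change at the digits printed from compound 1 to compound 4 (within the scatter). For the compounds shown here, a five-membered aromatic ring with one hetero atom therefore sits level at this place with the two substituted phenyl groups, which the earlier compounds, both six-membered carbon rings here, could not show. Nothing available explains this lack of change.

Still open, from the compounds shown here alone, is whether a basic amine or a carboxylic acid at this place would move the number beyond the scatter. Whether a pyridine ring would do so is equally unresolved.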